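Swapping a butyl chain for a halogenated sulfonyl group

The compounds below may be only part of what the source reports. "The series", "measured", "known", "first", "only" and "open" are said of these compounds alone.

Compound 1, with the structure `COc1ccc([C@H]2CC(=O)N(c3ccc(N)cc3)C2)cc1OC1CCCC1`, shares its core with the other compounds here. In a functional assay on HEK293 cells (Homo sapiens) for cytotoxicity (a lower number here means that less compound is tolerated, a higher number that more compound is tolerated), compound 1 gives only a limit, > 10000 nM. Compound 2, `COc1ccc([C@H]2CC(=O)N(c3ccc(S(C)(=O)=O)cc3)C2)cc1OC1CCCC1`, also gives only a limit in this assay, > 10000 nM. The step that the two limits leave unreadable from compound 1 to compound 2 therefore cannot be read. Compound 3, `CCCCNc1cccc(N2C[C@@H](c3ccc(OC)c(OC4CCCC4)c3)CC2=O)c1`, likewise gives only a limit in this assay, > 10000 nM; it stands with the two others at the edge of what the assay reports, because of the limit of > 10000 nM in this assay, at which 3 of the 3 values shown sit. The unmeasured compound 4 is `COc1ccc([C@H]2CC(=O)N(c3cccc(NS(=O)(=O)c4c(Br)nn(C)c4Cl)c3)C2)cc1OC1CCCC1`. The change is (3-bromo-5-chloro-1-methyl-1H-pyrazol-4-yl)sulfonyl in place of butyl on a nitrogen on an aromatic ring. Among the measured compounds shown here, no measured step bears on this change, and no step that could be read exists at all, so no direction can be drawn from the data; the only guide is that every compound so far sits at the limit. The step from compound 3 to compound 4 is therefore expected to be a step that the limit leaves unreadable from compound 3 to compound 4, essentially none beyond the scatter. Compound 4 is expected to give about 15000 nM in this assay, with a range from 5000 nM to 50000 nM.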

Compound 4, half-maximal cytotoxic concentration: > 10000 nM
Compound 4 ended at the assay's limit; the forecaster's own chance of this, stated with the estimate: 80%; the middle value does not contradict the limit.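

The step from compound 3 to compound 4 in this assay cannot be read, because both compounds give only a limit: the limit of > 10000 nM in this assay, at which 4 of the 4 values shown sit.

The compounds shown leave open how much of any of them the cells tolerate, and whether replacing butyl with the sulfonyl group changes that at all.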